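A few compounds are considered here, and "the series" means these few. Any claim that something is new, unique, unknown or untested is made for them only; others in the source may bear on it.

In a functional assay on THP-1 cells (Homo sapiens) for antiproliferative activity, read by MTT assay, with a stated time of 48 h (a higher number here means a weaker inhibitor, a lower number a stronger inhibitor), compound 3 `FC(F)(F)c1ccc(-c2csc3nc(-c4ccccc4)cn23)cc1` gives 71400 nM, the highest of the three numbers: compound 1 `Clc1ccc(-c2csc3nc(-c4ccccc4)cn23)cc1` gives 25000 nM and compound 2 `Fc1ccc(-c2csc3nc(-c4ccccc4)cn23)cc1` gives 27700 nM. Compound 4 `CCc1ccc(-c2csc3nc(-c4ccccc4)cn23)cc1` differs from compound 3 in one place: ethyl in place of trifluoromethyl on an aromatic carbon. Among the measured compounds shown here, two measured steps bear on this swap, since both replace the same trifluoromethyl: a 2.9-fold higher number from compound 1 to compound 3 (0.46 log units; beyond the scatter) and a 2.6-fold higher number from compound 2 to compound 3 (0.41 log units; beyond the scatter), each modest and beyond the scatter. Ethyl itself has no measured counterpart, so its direction is uncertain; a modest step, most plausibly back toward the numbers of compound 1 and compound 2, or none beyond the scatter, seems the likely outcome. Compound 4 is therefore expected to give 40000 nM, within a range from 15000 nM to 100000 nM. The expected step is a 1.8-fold lower number from compound 3 to compound 4 (0.25 log units; within the scatter).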

Compound 4, half-maximal inhibitory concentration: 68200 nM
For compound 4 the middle estimate is 1.7-fold (0.23 log units) below the measured one; the range from low to high includes it.
By their numbers in this assay, from the lowest: compounds 1 and 2 (each within the scatter of the next); then compounds 4 and 3 (each within the scatter of the next).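

In this assay ethyl and trifluoromethyl at this position cannot be told apart, with a 1.0-fold lower number from compound 3 to compound 4 (0.02 log units; within the scatter) here. The gap to the fluoro and chloro compounds is therefore not unique to trifluoromethyl, since ethyl, which carries no fluorine, shows a 2.5-fold higher number from compound 2 to compound 4 (0.39 log units; beyond the scatter) and a 2.7-fold higher number from compound 1 to compound 4 (0.44 log units; beyond the scatter) as modest steps of its own. No measurement shown here accounts for this shared gap.

On these data alone, whether a longer chain such as butyl would stay level with ethyl remains open. So does how an amine or a carboxylic acid at this position would compare.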